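Adding a fluoro group to compound 1

The source may hold more compounds than are shown below. What is called first, only, known or untested is meant among the compounds shown, and "the series" means these compounds.

Compound 1 `Fc1ccc2ncnc(Nc3cccc(Cl)c3)c2c1`: 311 nM
Compound 2 `Cc1cccc(Nc2ncnc3ccc(F)cc23)c1`: 1350 nM

In a functional assay on HEK293 cells for antagonist activity at metabotropic glutamate receptor 5 (Rattus norvegicus), read by calcium flux (a higher number here means a weaker inhibitor, a lower number a stronger inhibitor), compound 1 gives 311 nM, the lowest of the two numbers measured. Its nearest neighbour is compound 2, which lies a step of a 4.3-fold higher number from compound 1 to compound 2 (0.64 log units; beyond the scatter) away, a change that swaps one group for another on the same ring.

The step followed here leads from compound 1 to compound 3 `Fc1ccc2ncnc(Nc3ccc(F)c(Cl)c3)c2c1`. In this compound (fluoro in place of hydrogen on an aromatic carbon). For the measured compounds named here, no measured step bears directly on this change: the only comparison available concerns a methyl in place of a chloro, not a fluoro added to a hydrogen position. With nothing pointing either way, the expectation is that compound 3 stays close to compound 1 in this assay, with no step beyond the scatter.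

Compound 3 is therefore estimated at 300 nM, in a range from 100 nM to 900 nM. That estimate corresponds to an expected step of a 1.0-fold lower number from compound 1 to compound 3 (0.02 log units; within the scatter).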

Compound 3, half-maximal inhibitory concentration: > 10000 nM
Compound 3: a limit, no number; the forecaster's own chance of this, stated with the estimate: 5%; at least 33-fold (1.52 log units) between middle value and limit.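

In this assay compound 3 gives > 10000 nM, which is a limit of the assay and not a number. Placing a single fluoro on an aromatic carbon, ortho to a chloro group and para to a large group, gives an at least 32-fold higher number from compound 1 to compound 3 (1.50 log units; beyond the scatter), whereas swapping the chloro group for methyl gave only a 4.3-fold higher number from compound 1 to compound 2 (0.64 log units; beyond the scatter), so this ring can respond far more sharply to one small change than the earlier pair showed. The full size of the loss cannot be read because the result stands at the limit: the limit of > 10000 nM in this assay, at which 1 of the 3 values shown sits.

The compounds shown leave open whether this loss is particular to fluoro or would also follow from another group on the same carbon, such as a methoxy group or an amine. They also leave open whether fluoro there would cost as much without the neighbouring chloro group.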